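The source may report more compounds than this note shows. Statements on the series, on what has been measured and on what is new or still open speak of the compounds shown alone.

Compound 1 `CC(C)n1ncc2c(C(=O)Nc3c(F)cccc3F)cc(-c3cccs3)nc21` was tested in an ADME assay on LLC-MK2 cells (Macaca mulatta) for cytotoxicity, read by spectrophotometry and crystal violet staining, with a stated time of 4 days; on this read-out higher numbers stand for lower toxicity in this test and lower numbers for higher toxicity in this test. In this assay compound 1 gives only a limit, > 200000 nM, and no number. Compound 2 `CC(C)n1ncc2c(C(=O)Nc3ccccc3F)cc(-c3ccccn3)nc21` gives 100000 nM in this assay. For the measured compounds named here, compound 1 thus stands at the edge of what the measurement reports, as the limit of > 200000 nM in this assay, at which 1 of the 2 values shown sits, shows, and there is no measured step in this assay between it and any other compound. Compound 3 `CC(C)n1ncc2c(C(=O)Nc3cccc(F)c3F)cc(-c3cccs3)nc21` has not been measured in this assay. It differs from compound 1 in one place: 2,3-difluorophenyl in place of 2,6-difluorophenyl on an amide-type nitrogen. The two structures hold the same atoms, joined differently, and the change sits on an amide-type nitrogen whose other neighbours are a carbonyl carbon. No step between measured compounds is available, so the size of the change cannot be read from the numbers shown; with compound 1 already at the limit, the expected step of a number no higher from compound 1 to compound 3 (the limit leaves the size open) in this assay is none beyond the usual scatter. For compound 3 the estimated value in this assay is 200000 nM, with a range from 100000 nM to 400000 nM, and it is expected that this assay may again report only a limit.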

Compound 3, half-maximal cytotoxic concentration: 75000 nM
Estimate against measurement, compound 3: 2.7-fold (0.43 log units) above; the whole stated range lies above it.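

On the amide-type nitrogen, 2,3-difluorophenyl in place of 2,6-difluorophenyl gives, in this assay, an at least 2.6-fold lower number from compound 1 to compound 3 (0.42 log units; beyond the scatter). For the compounds shown here, this is the first measured step, and it shows that the read-out at this position responds to how the two fluorines are arranged on the ring, even though the two compounds hold the same atoms; the direction is toward higher toxicity in this test. The step has a lower bound and no fixed size, since the figure for compound 1 is a limit and not a number: the limit of > 200000 nM in this assay, at which 1 of the 3 values shown sits.

With a single step at this position, the compounds shown leave open whether the same change would give a similar shift in compounds that differ elsewhere on the shared core, including the group that separates compound 1 from compound 2. They also leave open how a plain phenyl, a chlorophenyl or a methoxyphenyl on this amide-type nitrogen would compare with the two difluorophenyl groups in this assay.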